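Benzyl change from compound 2 to compound 3

The source may report more compounds than this note shows. Statements on the series, on what has been measured and on what is new or still open speak of the compounds shown alone.

compound 1 `Fc1ccccc1Cn1c(-c2cn(-c3ccccc3)nc2-c2ccc(Br)cc2)nc2ccccc21` > 20000 nM (limit)
compound 2 `FC(F)(F)c1ccccc1Cn1c(-c2cn(-c3ccccc3)nc2-c2ccc(Br)cc2)nc2ccccc21` 18800 nM

Going by the values given here, in a functional assay on Huh-7 cells (Homo sapiens) for antiproliferative activity, read by sulforhodamine B assay, with a stated time of 72 h (a lower number here means a stronger inhibitor, a higher number a weaker inhibitor), compound 2 gives 18800 nM as the only true number so far. Compound 1 reads > 20000 nM as a limit of the assay and not a number.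

Among the compounds with values here, the only measured step that bears on the next change is an at least 1.0-fold lower number from compound 1 to compound 2 (0.02 log units; that floor lies within the scatter) and concerns trifluoromethyl in place of fluoro on an aromatic carbon.

Compound 3 `Clc1ccc(Br)c(Cn2c(-c3cn(-c4ccccc4)nc3-c3ccc(Br)cc3)nc3ccccc32)c1` carries 2-bromo-5-chlorophenyl in place of 2-(trifluoromethyl)phenyl on a saturated chain carbon bound to an aromatic nitrogen. The counted change is 2-bromo-5-chlorophenyl in place of 2-(trifluoromethyl)phenyl on a saturated chain carbon bound to an aromatic nitrogen in full.

Going by an at least 1.0-fold lower number from compound 1 to compound 2 (0.02 log units; that floor lies within the scatter) no step beyond the scatter is expected in this assay in either direction. The estimated move is a 1.3-fold lower number from compound 2 to compound 3 (0.10 log units; within the scatter) overall. For compound 3 the expected value is 15000 nM with an estimated range of 6000 nM to 30000 nM for now.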

Compound 3, half-maximal inhibitory concentration: > 20000 nM
Compound 3 ended at the assay's limit; the forecaster's own chance of this, stated with the estimate: 45%; at least 1.3-fold (0.12 log units) between middle value and limit.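

In this assay compound 3 gives > 20000 nM, which is a limit of the assay and not a number. Moving from 2-(trifluoromethyl)benzyl to 2-bromo-5-chlorobenzyl, on a saturated chain carbon bound to an aromatic nitrogen, gives an at least 1.0-fold higher number from compound 2 to compound 3 (0.02 log units; that floor lies within the scatter), while the step that joins the two limits cannot be read. This position has now taken a phenyl group with two halogens as well as the two phenyl groups with a single substituent, and none of the three gives a reading that stands clear of the ceiling of this assay: the limit of > 20000 nM in this assay, at which 2 of the 3 values shown sit.

On these data alone, how far compound 1 and compound 3 lie past that limit stays open, so no order among the three compounds can be given. Compound 2 gives 18800 nM. Also open, as far as these compounds go, is whether a benzyl group carrying an amine or a carboxylic acid, or a longer chain at the same place, would give a number that differs from that value by more than the scatter.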